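This account rests on a few compounds, and the source may have more. Where it says the series, first, only, none or still open, it means among the compounds named here.

In a functional assay on HeLa cells (Homo sapiens) for antiproliferative activity, read by CCK-8 assay, with a stated time of 72 h (a lower number here means a stronger inhibitor of growth, a higher number a weaker inhibitor of growth), compound 2 `CCCNC(=O)c1ccc2c(ccn2-c2ncc3c(n2)N(C2CCCC2)[C@H](CC)C(=O)N3C)c1` gives 238 nM and its relative compound 1 `CC[C@@H]1C(=O)N(C)c2cnc(-n3ccc4cc(C(=O)NC)ccc43)nc2N1C1CCCC1` gives 768 nM. The step of a 3.2-fold higher number from compound 2 to compound 1 (0.51 log units; beyond the scatter) comes with the change (hydrogen in place of ethyl on a saturated chain carbon bound to an amide-type nitrogen). Compound 3 `CCCCNC(=O)c1ccc2c(ccn2-c2ncc3c(n2)N(c2ccn(C)n2)C(CC)C(=O)N3C)c1` carries a different core; the difference between the two cores is not broken down here. In this assay compound 3 gives 4260 nM, the highest of the three measured numbers. Compound 4 `CCNC(=O)c1ccc2c(ccn2-c2ncc3c(n2)N(c2ccn(C)n2)C(CC)C(=O)N3C)c1` is not yet measured and differs from compound 3 by hydrogen in place of ethyl on a saturated chain carbon, two bonds along the chain from an amide-type nitrogen. Among the compounds with values here, this is the same kind of change as the one from compound 2 to compound 1, but the place is not identical: there the ethyl left a saturated chain carbon bound to an amide-type nitrogen, here it leaves a saturated chain carbon two bonds along the chain from that nitrogen. Within the data shown here, with only the step of a 3.2-fold higher number from compound 2 to compound 1 (0.51 log units; beyond the scatter) as a guide, and with the core of compound 3 differing, compound 4 is expected to move by about a 1.4-fold higher number from compound 3 to compound 4 (0.15 log units; within the scatter). Compound 4 is estimated at 6000 nM, within a range from 2000 nM to 18000 nM.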

Compound 4, concentration for 50% growth inhibition: 11100 nM
The estimate for compound 4 lay 1.9-fold (0.27 log units) below the measured number; the range from low to high includes it.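

In this assay, hydrogen in place of ethyl gives a 2.6-fold higher number from compound 3 to compound 4 (0.42 log units; beyond the scatter). Set beside the earlier step, the change carries over from one core to the other at much the same size: the same change on two cores in this assay, a 3.2-fold higher number (0.51 log units; beyond the scatter) from compound 2 to compound 1 and a 2.6-fold higher number (0.42 log units; beyond the scatter) from compound 3 to compound 4, 1.2-fold (0.09 log units) apart, within the scatter of two such steps This rests on only two pairs in a single assay, one going from propyl to methyl and the other from butyl to ethyl, so it does not show that the change would behave the same way on any further core or from any other chain length, and it does not explain why the number rises.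

Each core is shown with only two chain lengths, so the compounds leave open how all four chains would rank on one core. They also leave open whether a longer chain such as pentyl would lower the number further, and what a chain ending in an amine or a carboxylic acid would do.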